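The compounds below may be only part of what the source reports. "The series", "measured", "known", "first", "only" and "open" are said of these compounds alone.

Compound 1 `O=C(CSc1nc(Nc2ccccc2)c2ccccc2n1)Nc1ccccc1Cl` is one of three compounds that share a common core and differ only in the aryl group carried on the amide-type nitrogen. In a functional assay on MDA-MB-231 cells (Homo sapiens) for inhibition, read by MTT assay, with a stated time of 72 h (on this read-out lower numbers stand for stronger inhibition and higher numbers for weaker inhibition), compound 1 gives 24400 nM, the highest number of the three and therefore the weakest inhibition among them. Compound 2 `O=C(CSc1nc(Nc2ccccc2)c2ccccc2n1)Nc1ccc(Br)cc1` gives 11500 nM in this assay, and compound 3 `O=C(CSc1nc(Nc2ccccc2)c2ccccc2n1)Nc1ccc([N+](=O)[O-])cc1` gives 16800 nM. The step of a 2.1-fold lower number from compound 1 to compound 2 (0.33 log units; beyond the scatter) is a modest change beyond the scatter, whereas the step of a 1.5-fold lower number from compound 1 to compound 3 (0.16 log units; within the scatter) stays within it, so swapping the aryl group has so far moved the numbers only a little.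

Compound 4 `O=C(CSc1nc(Nc2ccccc2)c2ccccc2n1)Nc1ccc(F)c(Cl)c1` has not yet been measured in this assay. It differs from compound 1 in one place: 3-chloro-4-fluorophenyl in place of 2-chlorophenyl on an amide-type nitrogen. The closest guide is the step of a 2.1-fold lower number from compound 1 to compound 2 (0.33 log units; beyond the scatter), where another halogen-bearing phenyl group also replaced 2-chlorophenyl and the number fell modestly; the step of a 1.5-fold lower number from compound 1 to compound 3 (0.16 log units; within the scatter) suggests the effect may be small. A similar modest lowering, a 1.7-fold lower number from compound 1 to compound 4 (0.24 log units; within the scatter), is therefore expected for compound 4, giving an estimated 14000 nM with a likely range from 7000 nM to 30000 nM.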

Compound 4, half-maximal inhibitory concentration: 21600 nM
Compound 4: the middle estimate sits 1.5-fold (0.19 log units) below what was measured; the measured number falls inside the stated range.
By their numbers in this assay, from the lowest: compounds 2, 3, 4 and 1 (each within the scatter of the next, the first and the last beyond it).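

In this assay, putting 3-chloro-4-fluorophenyl in place of 2-chlorophenyl on the amide-type nitrogen gives a 1.1-fold lower number from compound 1 to compound 4 (0.05 log units; within the scatter), so this change has no effect that can be told from the scatter. The same group also stays within the scatter of the other two aryl groups, with a 1.3-fold higher number from compound 3 to compound 4 (0.11 log units; within the scatter) and a 1.9-fold higher number from compound 2 to compound 4 (0.27 log units; within the scatter), so compound 4 cannot be separated from compound 2 or compound 3. The four aryl groups now shown on this nitrogen therefore give closely similar numbers, and only compound 1 and compound 2 lie beyond the scatter of each other.

Still open, from the compounds shown here alone, is whether a different kind of group on this nitrogen, such as an aminophenyl, a carboxylic acid on the phenyl ring or a longer chain, would move the number further. Nothing available here explains why these aryl groups give such similar numbers.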